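This account rests on a few compounds, and the source may have more. Where it says the series, first, only, none or still open, it means among the compounds named here.

Three compounds of the series carry a number in an assay on cells for displacement of a labelled ligand from adenosine receptor A1 (Homo sapiens), with a stated time of 60 min, tested at 1 uM; on this read-out lower numbers stand for less inhibition and higher numbers for more inhibition at the one concentration tested (going by the name of the read-out). Compound 1 `CCOC(=O)C1=C(C)NC(=O)NC1C1CCCC1` gives 3%. Compound 2 `CCOC(=O)C1=C(C)N/C(=N\C#N)NC1c1ccco1` gives 27%. Compound 3 `CC1=C(C(=O)OC(C)C)C(C2CCCC2)NC(=O)N1` gives 1%. On these numbers compound 3 stands lowest of the three; its nearest neighbour is compound 1, higher by a margin within the scatter, and its furthest is compound 2, higher by a margin beyond the scatter. Among the measured compounds shown here, the only step measured in one place, a number 2 percentage points lower from compound 1 to compound 3 (within the scatter), is within the scatter.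

Compound 4 `CC1=C(C(=O)OC(C)C)C(c2ccccc2)NC(=O)N1` is not yet measured in this assay. It differs from compound 3 in one place: phenyl in place of cyclopentyl on a saturated ring carbon. For the measured compounds named here, no measured step touches the saturated ring carbon of the shared core; the step of a number 2 percentage points lower from compound 1 to compound 3 (within the scatter) concerns a different position and is within the scatter, so it gives no guide to the present change. Going by the values given here, compound 2 bears a different group on that saturated ring carbon, but its core also differs, so its value shows only that a higher number occurs. With nothing to support a move beyond the scatter, compound 4 is expected to stay close to compound 3, the estimated step of a number 5 percentage points higher from compound 3 to compound 4 (within the scatter) lying within the scatter. The estimate for compound 4 is 6%, with a range from -5% to 20%.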

Compound 4, a percentage reported as inhibition, at one concentration (the size of the read-out at that concentration, not a potency): 2%
The estimate for compound 4 lay 4 percentage points above the measured number; the range from low to high includes it.
By their numbers in this assay, from the lowest: compounds 3, 4 and 1 (each within the scatter of the next); then compound 2.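

In this assay, among the compounds shown here, this is the first measured step at the saturated ring carbon of the shared core: with phenyl in place of cyclopentyl, the result is a number 1 percentage points higher from compound 3 to compound 4 (within the scatter) and so does not separate the two rings. On this core, then, an aromatic six-membered carbon ring and a non-aromatic five-membered carbon ring, both without hydrogen-bond donors or acceptors, cannot be told apart at the one concentration tested. No measurement at hand explains this equivalence, and none shows how either ring is accommodated.

The pair leaves open whether a ring with a nitrogen, such as pyridyl, or a phenyl carrying an amine or a carboxylic acid, would move the number beyond the scatter at this position while the core stays the same. It also leaves open whether a longer chain at this position would do so, and whether the two rings would still match on the core of compound 2, where only a furan-bearing member is shown.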